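Diaryl urea series: extending the amino substituent

A few compounds are considered here, and "the series" means these few. Any claim that something is new, unique, unknown or untested is made for them only; others in the source may bear on it.

Compound 2 `Nc1cc(Oc2ccc(NC(=O)Nc3cccc(C(F)(F)F)c3)cc2)ncn1` gives 25 nM in an assay on isolated protein for inhibition of serine/threonine-protein kinase TNNI3K (Homo sapiens) (on this read-out lower numbers stand for stronger inhibition and higher numbers for weaker inhibition), the lowest of the three numbers in hand. Compound 3 `CNc1cc(Oc2ccc(NC(=O)Nc3cccc(C(F)(F)F)c3)cc2Cl)ncn1` gives 50 nM; the gap from compound 2 to compound 3 lies within the scatter. Compound 1 `CNc1cc(Oc2ccc(NC(=O)Nc3cccc(C(F)F)c3)cc2)ncn1` gives 100 nM, a gap from compound 2 that lies beyond the scatter. Within the data shown here, compounds 1 and 3 each differ from compound 2 in more than one place, so no single-point step is available. Compound 4 `CC(C)(O)CNc1cc(Oc2ccc(NC(=O)Nc3cccc(C(F)(F)F)c3)cc2)ncn1` carries the change (2-hydroxy-2-methylpropyl in place of hydrogen on a nitrogen on an aromatic ring), the amino becoming (2-hydroxy-2-methylpropyl)amino. With no single-point comparison to lean on, the expected step is small, toward a slightly higher number if anything: a 1.6-fold higher number from compound 2 to compound 4 (0.20 log units; within the scatter). For compound 4 the expected value in this assay is 40 nM, within 12 nM to 130 nM.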

Compound 4, half-maximal inhibitory concentration: 40 nM
Beside the measured number, compound 4's estimate shows no gap at the digits printed, within the range that was stated.
By their numbers in this assay, from the lowest: compounds 2, 4, 3 and 1 (each within the scatter of the next, the first and the last beyond it).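

Among these compounds, at the nitrogen on an aromatic ring, 2-hydroxy-2-methylpropyl in place of hydrogen gives a 1.6-fold higher number from compound 2 to compound 4 (0.20 log units; within the scatter) in this assay, the first single-point step. The two numbers cannot be told apart, so this position accepts the added chain with no change beyond the scatter. No evidence in hand bears on the reason for this result. Open, on these data alone, is whether a longer chain ending in an amine or a carboxylic acid at this nitrogen would stay within the scatter of compound 2. As far as these compounds go, the contribution of the hydroxyl within 2-hydroxy-2-methylpropyl also remains open.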